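This account rests on a few compounds, and the source may have more. Where it says the series, first, only, none or still open, it means among the compounds named here.

Measured so far:
compound 1, `CC(C)[C@@H]1CC[C@@H](C)C[C@@]12N(C)C(=O)[C@@H]1[C@H]3C(=O)NC(=O)[C@H]3ON12`, in a functional assay, read by spectrophotometry, with a stated time of 2 h (on this read-out higher numbers stand for weaker inhibition and lower numbers for stronger inhibition), compound 1 gives 1500 ug/mL
compound 2, `CC(C)[C@@H]1CC[C@@H](C)C[C@@]12N(C)C(=O)[C@@H]1[C@H]3C(=O)N(c4ccc(Cl)cc4)C(=O)[C@H]3ON12`, in this assay compound 2 gives 2000 ug/mL

Compound 2 carries the highest of the two numbers; compound 1 stands nearest, and the step of a 1.3-fold higher number from compound 1 to compound 2 (0.12 log units; within the scatter) lies within the scatter. Compound 3, `COc1ccc(N2C(=O)[C@H]3[C@H](ON4[C@@H]3C(=O)N(C)[C@@]43C[C@H](C)CC[C@H]3C(C)C)C2=O)cc1`, is not yet measured in this assay. It differs from compound 2 by methoxy in place of chloro on an aromatic carbon. Within the data shown here, the only measured step bearing on this, 4-chlorophenyl in place of hydrogen on an amide-type nitrogen in a ring, gave a 1.3-fold higher number from compound 1 to compound 2 (0.12 log units; within the scatter), nothing beyond the scatter. A further change on that same group is therefore expected to give no change at the digits printed from compound 2 to compound 3 (within the scatter), no shift beyond the scatter in either direction. For compound 3 the value in this assay is estimated at 2000 ug/mL, range 1000 ug/mL to 4000 ug/mL.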

Compound 3, half-maximal inhibitory concentration: 480 ug/mL
The estimate for compound 3 lay 4.2-fold (0.62 log units) above the measured number, and the stated range ends above it.
By their numbers in this assay, from the lowest: compound 3; then compounds 1 and 2 (each within the scatter of the next).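

Methoxy in place of chloro on this aromatic ring gives a 4.2-fold lower number from compound 2 to compound 3 (0.62 log units; beyond the scatter) in this assay and is the first change in the series beyond the scatter. Among these compounds, the 4-methoxyphenyl group in place of the amide hydrogen likewise gives a 3.1-fold lower number from compound 1 to compound 3 (0.49 log units; beyond the scatter) while the 4-chlorophenyl group showed no such step, so the group on the aromatic ring decides the outcome here. Nothing measured here accounts for this difference. Open, going by these compounds, is whether a hydroxy, ethoxy or dimethylamino group in the same place follows methoxy or chloro. Also open, on these data alone, is how an unsubstituted phenyl group compares.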